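A few compounds are considered here, and "the series" means these few. Any claim that something is new, unique, unknown or untested is made for them only; others in the source may bear on it.

Compound 1 `COC(=O)c1nnn([C@@H]2C(=O)N(c3ccc(C)cc3)[C@@H]2/C=C/c2ccccc2)c1C(=O)OC` gives "not determined" (no result reported) in a functional assay on KB cells (Homo sapiens) for inhibition; on this read-out higher numbers stand for weaker inhibition and lower numbers for stronger inhibition.
Compound 2 `Cc1ccc(N2C(=O)[C@@H](n3cc(-c4ccccc4)nn3)[C@H]2/C=C/c2ccccc2)cc1` gives 89200 nM in this assay.
Compound 3 `COC(=O)c1nnn([C@@H]2C(=O)N(C3CCCCC3)[C@@H]2/C=C/c2ccccc2)c1C(=O)OC` gives > 228000 nM in this assay, which is a limit of the assay and not a number.

Of the three compounds shown, compound 3 is the one that stands only at a limit, (the limit of > 228000 nM in this assay, at which 1 of the 3 values shown sits), so no single number places it; compound 1 has no result at all, and only compound 2 carries a measured number. Compound 4 `COC(=O)c1nnn([C@@H]2C(=O)N(c3ccc(Cl)cc3)[C@@H]2/C=C/c2ccccc2)c1C(=O)OC` has not yet been measured and differs from compound 3 in one place: 4-chlorophenyl in place of cyclohexyl on an amide-type nitrogen in a ring. Among the compounds with values here, no pair of measured compounds differs in a single place, so the size of any one change in this assay is not known from these data. Compound 2 does give a number rather than a limit, but it differs from compound 4 in more than one place. Compound 4 is expected to remain a weak inhibitor, near the top of the measured range, and a result given only as a limit would not be surprising. The estimated value for compound 4 is 150000 nM, with a range from 50000 nM to 300000 nM, which means an expected step of an at least 1.5-fold lower number from compound 3 to compound 4 (0.18 log units; that floor lies within the scatter).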

Compound 4, half-maximal inhibitory concentration: 145000 nM
Estimate against measurement, compound 4: 1.0-fold (0.01 log units) above, within the range that was stated.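

Within the data shown here, this is the first pair of measured compounds that differ in one place, the group on an amide-type nitrogen in a ring, and in this assay the change to 4-chlorophenyl gives an at least 1.5-fold lower number from compound 3 to compound 4 (0.19 log units; that floor lies within the scatter). For compound 3 the value is a limit of the assay and not a number: the limit of > 228000 nM in this assay, at which 1 of the 4 values shown sits. The step is therefore known only by its floor, so the real change could lie within the scatter or be larger, but compound 4 gives this position its first measured number.

On these data alone, it remains open whether the aromatic ring or the chlorine on it matters more here. Also open, as far as these compounds go, is how a plain phenyl, a 4-aminophenyl or a short chain such as ethyl would read on this nitrogen.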